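The source may report more compounds than this note shows. Statements on the series, on what has been measured and on what is new or still open speak of the compounds shown alone.

Measured so far:
compound 1 `COc1ccc(COC(=O)N(c2ccccc2)C2CN3CCC2CC3)cc1OC` — 550 nM in an assay on CHO cells for displacement of a labelled ligand from muscarinic acetylcholine receptor M5 (Homo sapiens), read by scintillation counting, with a stated time of 2 h; on this read-out lower numbers stand for stronger inhibition and higher numbers for weaker inhibition
compound 2 `O=C(OCCCc1ccccc1)N(c1ccccc1)C1CN2CCC1CC2` — 260 nM in this assay

Compound 2 stands lowest of the two numbers in this assay, and its nearest neighbour is compound 1, whose number is higher by a margin that lies beyond the usual scatter. Within the data shown here, no pair of measured compounds differs in a single place, so no measured step is available to calibrate the change that leads to compound 3 `COc1ccc(COC(=O)N(c2ccccc2)C2CN3CCC2CC3)cc1`, which has not yet been tested in this assay. Relative to compound 2, the change is 4-methoxyphenyl in place of phenethyl on a saturated chain carbon bound to an oxygen next to a carbonyl group. Compound 3 thus shares the shared core of compound 1 and compound 2 and also shares the carbamate ester oxygen and carbonyl with both. Because compound 1 gives 550 nM in this assay while compound 2 gives 260 nM, a modest upward step from compound 2 to compound 3 is expected, one that could well stay within the scatter. The estimated step is a 1.5-fold higher number from compound 2 to compound 3 (0.19 log units; within the scatter). Compound 3 is expected to give about 400 nM, with a plausible range from 150 nM to 1000 nM.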

Compound 3, inhibition constant: 470 nM
Beside the measured number, compound 3's estimate is 1.2-fold (0.07 log units) below it; the range from low to high includes it.
By their numbers in this assay, from the lowest: compounds 2, 3 and 1 (each within the scatter of the next, the first and the last beyond it).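

In this assay, the first single-place steps show that this position tolerates a change of chain and ring placement without a readable effect: 4-methoxyphenyl in place of phenethyl on a saturated chain carbon bound to an oxygen next to a carbonyl group gives a 1.8-fold higher number from compound 2 to compound 3 (0.26 log units; within the scatter). Put another way, 3-phenylpropyl and 4-methoxybenzyl cannot be told apart on this read-out, even though the swap brings in an oxygen and a hydrogen-bond acceptor that phenethyl lacks. The aromatic ring of the benzyl group behaves in the same way, as hydrogen in place of methoxy on an aromatic carbon gives a 1.2-fold lower number from compound 1 to compound 3 (0.07 log units; within the scatter), so neither single change moves the number beyond the usual scatter. No measurement at hand accounts for either step.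

The compounds shown leave open whether a basic amine or a carboxylic acid on this chain, or a chain longer than 3-phenylpropyl, would produce a step that can be read beyond the scatter. They also leave open whether a halogen such as chlorine, or a hydroxyl group, in place of methoxy on the aromatic ring would do so.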